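A few compounds are considered here, and "the series" means these few. Any claim that something is new, unique, unknown or untested is made for them only; others in the source may bear on it.

Compound 1 `COc1ccc(N2CCN(C(=S)SCc3ccc(C(=O)Nc4ccccc4N)cc3)CC2)cc1`: 28.1%
Compound 2 `Nc1ccccc1NC(=O)c1ccc(CSC(=S)N2CCCC2)cc1`: 30.2%
Compound 3 `COC(=O)c1ccc2c(c1)CCN2C(=S)SCc1ccc(C(=O)Nc2ccccc2N)cc1`: 37.5%

Of the compounds shown here, three have been tested in a functional assay on A-375 cells (Homo sapiens) for antiproliferative activity, read by CCK-8 assay, with a stated time of 72 h, tested at 2 uM; a lower number here means a weaker effect, a higher number a stronger effect of the compound at the concentration tested. Compound 1 stands at the bottom of the three numbers, yet compound 2 and compound 3 both fall within the usual scatter of it, so the three cannot be told apart on these data. Compound 4 `Cc1ccc(N2CCN(C(=S)SCc3ccc(C(=O)Nc4ccccc4N)cc3)CC2)cc1` differs from compound 1 in a single place: methyl in place of methoxy on an aromatic carbon. Among the compounds with values here, no measured pair shows this change, so nothing indicates how large a step it brings or in which direction. The step expected from compound 1 to compound 4 is a number 0.1 percentage points lower from compound 1 to compound 4 (within the scatter), that is, none beyond the scatter. Compound 4 is therefore estimated to give about 28%, in a range from 18% to 38%.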

Compound 4, a percentage reported as inhibition, at one concentration (the size of the read-out at that concentration, not a potency): 25.8%
Beside the measured number, compound 4's estimate is 2.2 percentage points above it; the measured number falls inside the stated range.
By their numbers in this assay, from the lowest: compounds 4, 1, 2 and 3 (each within the scatter of the next, the first and the last beyond it).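

Within the data shown here, putting methyl in place of methoxy on this aromatic carbon, para to a large group, gives the first measured step at this position: in this assay, it is a number 2.3 percentage points lower from compound 1 to compound 4 (within the scatter). At this single concentration, then, compound 1 and compound 4 cannot be told apart, so this swap of 4-methoxyphenyl for 4-methylphenyl leaves no measurable mark on the read-out. No available measurement points to a cause for this result. On these data alone, whether an amine or a carboxylic acid on the same carbon would give a step beyond the scatter remains open.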